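Methyl for Bromo on the Shared Core: Cytotoxicity Outlook

The source may hold more compounds than are shown below. What is called first, only, known or untested is meant among the compounds shown, and "the series" means these compounds.

Compound 1 `COc1ccc2c(OCC[C@@H]3NC(=O)N(C)CCCC/C=C\[C@@H]4C[C@@]4(C(=O)NS(=O)(=O)C4(C)CC4)NC3=O)cc(-c3nc(C(C)C)cs3)nc2c1Br`: 28300 nM
Compound 2 `CCC1(S(=O)(=O)NC(=O)[C@@]23C[C@H]2/C=C\CCCCN(C)C(=O)N[C@@H](CCOc2cc(-c4nc(C(C)C)cs4)nc4c(Cl)c(OC)ccc24)C(=O)N3)CC1`: 49300 nM
Compound 3 `COc1ccc2c(OCC[C@@H]3NC(=O)N(C)CCCC/C=C\[C@@H]4C[C@@]4(C(=O)NS(=O)(=O)C4(C#N)CC4)NC3=O)cc(-c3nc(C(C)C)cs3)nc2c1Cl`: > 75000 nM, a limit of the assay

In an ADME assay on cells (Homo sapiens) for activation (on this read-out higher numbers stand for lower toxicity in this test and lower numbers for higher toxicity in this test), compound 1 gives the lowest of the two numbers shown, and the nearest, compound 2, sits within the scatter of it. Compound 3 reaches only a limit of the assay (the limit of > 75000 nM in this assay, at which 1 of the 3 values shown sits). For the measured compounds named here, the single measured step, an at least 1.5-fold higher number from compound 2 to compound 3 (0.18 log units; that floor lies within the scatter), concerns a cyano in place of ethyl on a saturated ring carbon and does not touch the change now considered. Compound 4 `COc1ccc2c(OCC[C@@H]3NC(=O)N(C)CCCC/C=C\[C@@H]4C[C@@]4(C(=O)NS(=O)(=O)C4(C)CC4)NC3=O)cc(-c3nc(C(C)C)cs3)nc2c1C` differs from compound 1 by methyl in place of bromo on an aromatic carbon. Going by the values given here, no measured step bears on this change, so the expectation is no step beyond the scatter: a 1.1-fold higher number from compound 1 to compound 4 (0.03 log units; within the scatter). Compound 4 is estimated at 30000 nM, between 14000 nM and 65000 nM.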

Compound 4, half-maximal cytotoxic concentration: 31900 nM
Compound 4: the middle estimate sits 1.1-fold (0.03 log units) below what was measured; the measured number falls inside the stated range.
By their numbers in this assay, from the lowest: compounds 1, 4 and 2 (each within the scatter of the next). At a limit, above all of these: compound 3.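

At this position, on an aromatic carbon ortho to a methoxy group, methyl in place of bromo gives a 1.1-fold higher number from compound 1 to compound 4 (0.05 log units; within the scatter) in this assay and so stays within the scatter. On the shared core, this position therefore carries either group without a step beyond the scatter in this test. No measurement shown here explains this result. On these data alone, whether an amine, a carboxylic acid or a longer chain at this position would also stay within the scatter remains open.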